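The source may report more compounds than this note shows. Statements on the series, on what has been measured and on what is new or still open speak of the compounds shown alone.

Compound 1 `CCCCCCCCc1c(O)cc(C)oc1=O` is a pyranone carrying an octyl chain. Among the compounds with values here, in an ADME assay on L929 cells (Mus musculus, culture collection number NCTC 929) for cytotoxicity, read by MTT assay, with a stated time of 72 h (on this read-out higher numbers stand for weaker inhibition and lower numbers for stronger inhibition), compound 1 gives 145000 nM, the only true number among the two values shown. In this assay compound 2 `Cc1cc(O)c(C(=S)Nc2ccccc2)c(=O)o1` gives only a limit, > 200000 nM, not a measured number. That the limit of > 200000 nM in this assay, at which 1 of the 2 values shown sits, is where the second value sits. Compound 3 `CCCCCCc1c(O)cc(C)oc1=O` differs from compound 1 by hydrogen in place of ethyl on a saturated chain carbon, six bonds along the chain from an aromatic carbon. Within the data shown here, no measured pair shows such a shortening, so the step of a 1.2-fold higher number from compound 1 to compound 3 (0.09 log units; within the scatter) is expected to be small, toward weaker inhibition, and hardly beyond the usual scatter. For compound 3 the estimate is 180000 nM, ranging from 80000 nM to 400000 nM.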

Compound 3, half-maximal inhibitory concentration: > 200000 nM
Compound 3 gave a limit, no number; the forecaster's own chance of this, stated with the estimate: 45%; at least 1.1-fold (0.04 log units) between middle value and limit.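

Within the data shown here, this is the first measured pair for a change at this place on the chain: hydrogen in place of ethyl gives an at least 1.3-fold higher number from compound 1 to compound 3 (0.13 log units; that floor lies within the scatter). The direction fits weaker inhibition in this assay, but the floor of the step does not show a change beyond the usual scatter. Compound 3 is a limit, not a number, so only that floor is known and the full size of the step stays hidden: the limit of > 200000 nM in this assay, at which 2 of the 3 values shown sit.

On these data alone, whether a longer chain in place of the ethyl would bring a lower number stays open. So does the effect of an amine or a carboxylic acid there.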